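The compounds below may be only part of what the source reports. "The series", "measured", "known", "first", "only" and "open" are said of these compounds alone.

Measured compounds:

Compound 1, `CC(O)(CSc1cccc(C(F)(F)F)c1)C(=O)Nc1ccc(S(F)(F)(F)(F)F)cc1`: 26200 nM
Compound 2, `CC(O)(CSc1ccccc1C(F)(F)F)C(=O)Nc1ccc(S(F)(F)(F)(F)F)cc1`: 15800 nM
Compound 3, `CC(O)(CS(=O)(=O)c1cccc(C(F)(F)F)c1)C(=O)Nc1cccc(S(F)(F)(F)(F)F)c1`: 37300 nM

These three compounds were tested in a functional assay on DU-145 cells (Homo sapiens) for antiproliferative activity, read by propidium iodide staining, with a stated time of 96 h; on this read-out higher numbers stand for weaker inhibition and lower numbers for stronger inhibition. Compound 1 and compound 2 share a core and differ only in one place: 2-(trifluoromethyl)phenyl in place of 3-(trifluoromethyl)phenyl on a sulfur. That change gave a 1.7-fold lower number from compound 1 to compound 2 (0.22 log units; within the scatter). Compound 3 carries a different core, and the difference between the core of compound 3 and the core of compound 1 is not broken down here; their values show that compound 3 sits close to compound 1 in this assay and further from compound 2.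

Compound 4, `CC(O)(CS(=O)(=O)c1ccccc1C(F)(F)F)C(=O)Nc1cccc(S(F)(F)(F)(F)F)c1`, has not yet been measured in this assay. It differs from compound 3 by 2-(trifluoromethyl)phenyl in place of 3-(trifluoromethyl)phenyl on a sulfonyl sulfur. Going by the values given here, this is the same kind of change as the one from compound 1 to compound 2, but the place is not identical: in the earlier pair the sulfur bears only a saturated chain carbon as its other neighbour, while here it is a sulfonyl sulfur whose other neighbour is a saturated chain carbon. Compound 4 is expected to show a 1.6-fold lower number from compound 3 to compound 4 (0.21 log units; within the scatter), a step of about the size seen from compound 1 to compound 2, because the earlier change gave a 1.7-fold lower number from compound 1 to compound 2 (0.22 log units; within the scatter). The estimate for compound 4 is 23000 nM, expected within 10000 nM to 50000 nM.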

Compound 4, half-maximal inhibitory concentration: 27300 nM
The estimate for compound 4 lay 1.2-fold (0.07 log units) below the measured number; the range from low to high includes it.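

In this assay, 2-(trifluoromethyl)phenyl in place of 3-(trifluoromethyl)phenyl on a sulfonyl sulfur gave a 1.4-fold lower number from compound 3 to compound 4 (0.14 log units; within the scatter). Set beside the earlier step, the same change reads alike on the two cores: the same change on two cores in this assay, a 1.7-fold lower number (0.22 log units; within the scatter) from compound 1 to compound 2 and a 1.4-fold lower number (0.14 log units; within the scatter) from compound 3 to compound 4, 1.2-fold (0.08 log units) apart, within the scatter of two such steps. This shows that the change produced no large shift on either core, but each step lies within the scatter, so the pair does not show that a real effect of the change carries from one core to another, and two cores cannot establish a rule for the series.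

The compounds shown leave open whether a different group on the sulfur, such as an unsubstituted phenyl or a pyridine ring, would move the number beyond the scatter. They also leave open how the aryl change would read on a core carrying an amine in place of the hydroxyl, or on one with a longer chain.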